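Dropping a Methyl from a Benzyl Group in Macrophage Cytotoxicity

This account rests on a few compounds, and the source may have more. Where it says the series, first, only, none or still open, it means among the compounds named here.

Four compounds built on two different cores were compared for how strongly they harm mouse macrophage cells in an ADME assay on J774.1 cells (Mus musculus) for cytotoxicity, with a stated time of 48 h; on this read-out lower numbers stand for an effect already at smaller amounts and higher numbers for an effect only at larger amounts of compound. Compound 1 `COC(=O)C1C(=O)C(C(=O)OC)[C@H](c2cccc([N+](=O)[O-])c2)N(Cc2ccccc2)[C@@H]1c1cccc([N+](=O)[O-])c1` and compound 2 `COC(=O)C1C(=O)C(C(=O)OC)[C@H](c2cccc([N+](=O)[O-])c2)N(Cc2ccc(C)cc2)[C@@H]1c1cccc([N+](=O)[O-])c1` share one core; compound 3 `COC(=O)C1=C(O)C[C@H](c2ccccn2)N(Cc2ccc(C)cc2)[C@@H]1c1ccccn1` and compound 4 `COC(=O)C1=C(O)C[C@H](c2ccccn2)N(Cc2ccccc2)[C@@H]1c1ccccn1` share another. How the two cores differ is not broken down here.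

In this assay compound 2 gives 49.8 uM. For compound 1 the assay reports only a limit, > 100 uM, not a number. This is described as the limit of > 100 uM in this assay, at which 1 of the 3 values shown sits. The change from compound 2 to compound 1 is hydrogen in place of methyl on an aromatic carbon, and it made a step of an at least 2.0-fold higher number from compound 2 to compound 1 (0.30 log units; that floor lies within the scatter).

In this assay compound 3 gives 34.9 uM, and its gap to compound 2 lies within the scatter. Compound 4 has not yet been measured. The change from compound 3 to compound 4 is hydrogen in place of methyl on an aromatic carbon, the same change as from compound 2 to compound 1, at a place that reads the same word for word.

Compound 4 is therefore expected to sit at a step of a 2.0-fold higher number from compound 3 to compound 4 (0.30 log units; within the scatter) from compound 3 because the same change from compound 2 to compound 1 gave an at least 2.0-fold higher number from compound 2 to compound 1 (0.30 log units; that floor lies within the scatter). The estimate for compound 4 is 70 uM, expected to fall between 35 uM and 150 uM.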

Compound 4, concentration for half-maximal effect: 33.2 uM
For compound 4 the middle estimate is 2.1-fold (0.32 log units) above the measured one; measured number outside the range, below it.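

In this assay, among these compounds, swapping the 4-methylbenzyl group for benzyl on the core of compound 3, which puts hydrogen in place of methyl on the aromatic ring, gave a 1.1-fold lower number from compound 3 to compound 4 (0.02 log units; within the scatter), so on this core the change produced no step that can be told apart from ordinary repeat-to-repeat variation. Compound 1 stands at > 100 uM, which is a limit of the assay and not a number. The same swap on two cores therefore gives one readable step and one that is only partly pinned down, so these two pairs neither show that the change carries over from one core to the other nor show that it fails to: the same change on two cores in this assay, an at least 2.0-fold higher number (0.30 log units; that floor lies within the scatter) from compound 2 to compound 1 and a 1.1-fold lower number (0.02 log units; within the scatter) from compound 3 to compound 4; the limit leaves it open whether they differ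

The compounds shown leave open what other groups would do at this place on the six-membered aromatic ring, since only methyl and hydrogen appear there, and a chlorine atom, a methoxy group, an amine or a carboxylic acid could be read against the same pairs. They also leave open how the swap would read on any further core, as two pairs on two cores are too few to support a rule for the whole series.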